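The compounds below may be only part of what the source reports. "The series", "measured", "known", "first", "only" and "open" are said of these compounds alone.

Compound 1 `O=C(NC1CCCCCC1)c1c(-c2ccccc2)c(Br)cn(Cc2ccc(F)cc2)c1=O` — in an assay on HEK293 cells for inhibition of Lysophosphatidylserine lipase ABHD12 (Homo sapiens), with stated times of 30 min and 5 min (a higher number here means a weaker inhibitor, a lower number a stronger inhibitor), compound 1 gives > 10000 nM, which is a limit of the assay and not a number.
Compound 2 `COc1ccc(-c2c(Br)cn(Cc3ccc(F)cc3)c(=O)c2C(=O)NC2CCCCCC2)cc1` — in this assay compound 2 gives > 10000 nM, again a limit of the assay rather than a number.

Compound 1 therefore stands at the limit of this assay, with no measured number of its own. Within the data shown here, the one measured step, a step that the two limits leave unreadable from compound 1 to compound 2, cannot be read for size, since both of its ends rest at the same limit (the limit of > 10000 nM in this assay, at which 2 of the 2 values shown sit). That step concerns a methoxy in place of hydrogen on an aromatic carbon and does not touch the change now in question.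

Compound 3 `O=C(NC1CCCCCC1)c1c(-c2ccccc2)ccn(Cc2ccc(F)cc2)c1=O` differs from compound 1 by hydrogen in place of bromo on an aromatic carbon. Among the measured compounds shown here, no measured pair of compounds shows what this change does in this assay, so the expectation for compound 3 can rest only on where compound 1 stands, at the limit. Compound 3 is therefore expected to be reported at 20000 nM, within an estimated range of 4000 nM to 100000 nM. The expected step that the limit leaves unreadable from compound 1 to compound 3 is accordingly none beyond the scatter, and the most likely outcome for compound 3 is once more a limit rather than a number.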

Compound 3, half-maximal inhibitory concentration: > 10000 nM
Compound 3: a limit, no number (the forecaster's own chance of this, stated with the estimate: 80%); the middle value does not contradict the limit.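

Compound 3, like compound 1, rests at a limit of this assay and not at a number, so the step from bromo to hydrogen between these two compounds cannot be read: the limit of > 10000 nM in this assay, at which 3 of the 3 values shown sit.

The compounds shown leave open how strongly any of them inhibits the lipase, and whether this change has any effect on inhibition.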